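Acid side chain replaced by an amide on the shared core

The source may hold more compounds than are shown below. What is called first, only, known or untested is meant among the compounds shown, and "the series" means these compounds.

Measured compounds:
compound 1 `Cc1nc(-c2ccc(C(F)(F)F)cc2)sc1CNc1ccc(CC(=O)O)cc1`: 18% in a functional assay on CHO cells for agonist activity at Free fatty acid receptor 1 (Homo sapiens), read by a luciferase reporter; on this read-out lower numbers stand for smaller maximal responses and higher numbers for larger maximal responses
compound 2 `Cc1nc(-c2ccc(C(F)(F)F)cc2)sc1CNc1ccc(CCCC(=O)O)cc1`: 44% in this assay
compound 3 `O=C(O)COc1ccc(NCc2cccc(Oc3ccccc3)c2)cc1`: 84% in this assay

Compound 3 stands highest of the three; compound 2 is nearest and compound 1 furthest, both beyond the scatter. Compound 4 `NC(=O)CCc1ccc(NCc2cccc(Oc3ccccc3)c2)cc1` differs from compound 3 by 2-carbamoylethyl in place of carboxymethoxy on an aromatic carbon. For the measured compounds named here, the one measured step, a number 26 percentage points higher from compound 1 to compound 2 (beyond the scatter), replaces carboxy by 2-carboxyethyl and so bears only loosely on the present change; no measured pair puts 2-carbamoylethyl in place of carboxymethoxy. The expectation for this assay therefore rests on little, and the range is set wide, leaning toward a lower number than compound 3. Compound 4 is estimated at 45%, between 10% and 85%. The expected step is a number 39 percentage points lower from compound 3 to compound 4 (beyond the scatter).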

Compound 4, largest response reached (reported as percent of maximum), in percent of the reference or control that the assay uses: 68%
Beside the measured number, compound 4's estimate is 23 percentage points below it; low and high end bracket the measured number.
By their numbers in this assay, from the lowest: compound 1; then compound 2; then compound 4; then compound 3.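

In this assay the exchange of carboxymethoxy for 2-carbamoylethyl, on an aromatic carbon para to a large group, gives a number 16 percentage points lower from compound 3 to compound 4 (beyond the scatter) and is a modest step. At this position a sizeable maximal response therefore survives without a carboxylic acid, with compound 4 at 68% in this assay. No measurement at hand bears on what lies behind this step.

From the compounds shown here alone, since the acid and the chain oxygen leave together, their separate shares remain open. A propanoic acid chain or a tetrazole at this position could separate them.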